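Piperidin-1-yl for thiophen-3-yl: forecast for compound 4

The source may report more compounds than this note shows. Statements on the series, on what has been measured and on what is new or still open speak of the compounds shown alone.

Measured so far in an assay on isolated protein for antagonist activity at prostaglandin E2 receptor EP1 subtype (Homo sapiens), read by reporter gene assay; a higher number here means a weaker inhibitor, a lower number a stronger inhibitor:
compound 1 `O=C(O)c1csc(-n2nc(-c3ccc(Cl)cc3)c3ccccc32)n1` — 12 nM
compound 2 `COc1ccc(-c2nn(-c3nc(C(=O)O)cs3)c3ccccc23)cc1` — 4 nM
compound 3 `O=C(O)c1csc(-n2nc(-c3ccsc3)c3ccccc32)n1` — 30 nM

Compound 3 gives the highest number of the three, that is the weakest inhibition: the step of a 2.5-fold higher number from compound 1 to compound 3 (0.40 log units; beyond the scatter) and the step of a 7.5-fold higher number from compound 2 to compound 3 (0.88 log units; beyond the scatter) both lie beyond the scatter. Compound 2 and compound 1 are separated by a 3.0-fold lower number from compound 1 to compound 2 (0.48 log units; beyond the scatter).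

Compound 4 `O=C(O)c1csc(-n2nc(N3CCCCC3)c3ccccc32)n1` is not yet measured. Its change from compound 3 is piperidin-1-yl in place of thiophen-3-yl on an aromatic carbon. Among the compounds with values here, none of the measured steps contains this kind of change: every step so far exchanges one aromatic ring for another aromatic ring, or a substituent on such a ring, and the spread over all three compounds is the step from compound 2 to compound 3. Within the data shown here, the nearest precedent is the step of a 2.5-fold higher number from compound 1 to compound 3 (0.40 log units; beyond the scatter), which already moved the number upward when a thiophen-3-yl replaced the 4-chlorophenyl. Exchanging the remaining aromatic ring for a non-aromatic one is a larger departure from the series, so a further rise in number is expected, with wide uncertainty. In this assay compound 4 is estimated at 120 nM, with a range of 30 nM to 500 nM. The expected step is therefore a 4.0-fold higher number from compound 3 to compound 4 (0.60 log units; beyond the scatter).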

Compound 4, half-maximal inhibitory concentration: 16 nM
Beside the measured number, compound 4's estimate is 7.5-fold (0.88 log units) above it; the whole stated range lies above it.
By their numbers in this assay, from the lowest: compound 2; then compounds 1, 4 and 3 (each within the scatter of the next, the first and the last beyond it).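

In this assay, a non-aromatic ring at this position sits level with two of the aromatic groups: piperidin-1-yl in place of thiophen-3-yl gives a 1.9-fold lower number from compound 3 to compound 4 (0.27 log units; within the scatter), and piperidin-1-yl in place of 4-chlorophenyl gives a 1.3-fold higher number from compound 1 to compound 4 (0.12 log units; within the scatter). Within the data shown here, an aromatic ring on this carbon is therefore not required for a value in this range, which the earlier compounds, all aromatic here, could not show; only the 4-methoxyphenyl group stands apart, with a 4.0-fold higher number from compound 2 to compound 4 (0.60 log units; beyond the scatter). No measurement at hand accounts for this result.

The compounds shown leave open whether other non-aromatic groups on this carbon, such as morpholin-4-yl, pyrrolidin-1-yl or an open-chain diethylamino group, would read like piperidin-1-yl, and whether a methoxy group on the piperidine ring would bring the number towards that of compound 2. They also leave open whether this tolerance holds when the carboxylic acid, common to all four compounds, is replaced by a primary amide or a tetrazole.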